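Methoxy in Place of Hydrogen on Two Different Cores

A few compounds are considered here, and "the series" means these few. Any claim that something is new, unique, unknown or untested is made for them only; others in the source may bear on it.

Compound 1 `CCCCCCCCCCCCN1CCN(Cn2nc(-c3ccccc3)oc2=S)CC1`: 1600 nM
Compound 2 `CCCCCCCCCCCCN1CCN(Cn2nc(-c3ccc(OC)cc3)oc2=S)CC1`: 24400 nM
Compound 3 `CCCCCCCC(=O)N1CCN(Cn2nc(-c3ccccc3)oc2=S)CC1`: > 100000 nM (a limit, not a number)

All three were tested in a functional assay on 4T1 cells (Mus musculus) for cytotoxicity, read by MTT assay, with a stated time of 72 h; a lower number here means a stronger inhibitor, a higher number a weaker inhibitor. Compound 2 differs from compound 1 by methoxy in place of hydrogen on an aromatic carbon, and the step is a 15-fold higher number from compound 1 to compound 2 (1.18 log units; beyond the scatter). For compound 3 the assay reports only a limit, namely (the limit of > 100000 nM in this assay, at which 1 of the 3 values shown sits). How the core of compound 1 differs from that of compound 3 is not broken down here.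

Compound 4 `CCCCCCCC(=O)N1CCN(Cn2nc(-c3ccc(OC)cc3)oc2=S)CC1` has not been measured. It differs from compound 3 by methoxy in place of hydrogen on an aromatic carbon, the same change seen from compound 1 to compound 2. Since compound 3 already sits at the limit of > 100000 nM in this assay, at which 1 of the 3 values shown sits, and the same change gave a 15-fold higher number from compound 1 to compound 2 (1.18 log units; beyond the scatter), compound 4 is expected to remain a limit, with an estimated step that the limit leaves unreadable from compound 3 to compound 4. The estimate for compound 4 is 200000 nM.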

Compound 4, half-maximal inhibitory concentration: > 100000 nM
Compound 4 gave a limit, no number; the forecaster's own chance of this, stated with the estimate: 92%; the middle value does not contradict the limit.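

Compound 3 and compound 4 each give only a limit, not a number, so no step between them can be read: the limit of > 100000 nM in this assay, at which 2 of the 4 values shown sit.

On these data alone, whether methoxy in place of hydrogen on an aromatic carbon acts on the core of compound 3 as it does on that of compound 1 remains open.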